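Aryl swap on the shared core: compound 2 to compound 4

The source may report more compounds than this note shows. Statements on the series, on what has been measured and on what is new or still open speak of the compounds shown alone.

Measured so far:
compound 1 `CCOC(=O)/C(=C/c1ccccc1)CN1C(=O)[C@@H](OC)[C@H]1c1ccc(Cl)cc1` — 12700 nM
compound 2 `COC(=O)/C(=C/c1ccccc1)CN1C(=O)[C@@H](OC)[C@H]1c1ccc(Cl)cc1` — 15300 nM
compound 3 `COc1ccc(OC)c([C@@H]2[C@H](OC)C(=O)N2C/C(C#N)=C/c2ccccc2)c1` — no result reported

In a functional assay on MCF7 cells (Homo sapiens) for antiproliferative activity, read by MTT assay, with a stated time of 48 h (on this read-out lower numbers stand for stronger inhibition and higher numbers for weaker inhibition), compound 1 gives 12700 nM and compound 2 gives 15300 nM. Within the data shown here, the one measured step is a 1.2-fold higher number from compound 1 to compound 2 (0.08 log units; within the scatter), so compound 2 stands highest of the two numbers, with compound 1 nearest and within the scatter. Compound 3 has no result in this assay.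

Compound 4 `COC(=O)/C(=C/c1ccccc1)CN1C(=O)[C@@H](OC)[C@H]1c1cccc(F)c1` is compound 2 with one change: 3-fluorophenyl in place of 4-chlorophenyl on a saturated ring carbon. Among the measured compounds shown here, no measured step touches this position; the step from compound 1 to compound 2 concerns a different part of the shared core and gives no guide here. With nothing to build on, the expected step is a 1.3-fold higher number from compound 2 to compound 4 (0.12 log units; within the scatter), none beyond the scatter. Compound 4 is estimated at 20000 nM, range 7000 nM to 60000 nM.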

Compound 4, half-maximal inhibitory concentration: 13700 nM
Compound 4: middle estimate off by 1.5-fold (0.16 log units), on the high side; the range from low to high includes it.
By their numbers in this assay, from the lowest: compounds 1, 4 and 2 (each within the scatter of the next).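

In this assay, among these compounds, 3-fluorophenyl in place of 4-chlorophenyl on the saturated ring carbon gives a 1.1-fold lower number from compound 2 to compound 4 (0.05 log units; within the scatter) and is the first reading at this position. The halogen and its place on the phenyl ring change together here, and this pair cannot separate the two changes, yet the number stays within the scatter. No evidence on the cause of this result is available.

Still open, from the compounds shown here alone, is whether a phenyl ring carrying an amine or a carboxylic acid at this carbon would give a step beyond the scatter.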